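The source may hold more compounds than are shown below. What is called first, only, known or untested is meant among the compounds shown, and "the series" means these compounds.

Two analogues of the shared core have been run in a functional assay on PA-1 cells (Homo sapiens) for cytotoxicity, read by MTT assay, with a stated time of 48 h; a lower number here means a stronger inhibitor, a higher number a weaker inhibitor. Compound 1 `COc1ccc(-c2ccnc(Nc3ccc4c(c3)c(/C=C3/C(=O)Nc5ccccc53)cn4C)n2)cc1` gives > 100000 nM, which is a limit of the assay and not a number. Compound 2 `Cn1cc(/C=C2/C(=O)Nc3ccccc32)c2cc(Nc3nccc(-c4ccc(Cl)cc4)n3)ccc21` gives 2430 nM in this assay. Among the measured compounds shown here, the single measured step, an at least 41-fold lower number from compound 1 to compound 2 (1.61 log units; beyond the scatter), is large; the evidence for it rests on (the limit of > 100000 nM in this assay, at which 1 of the 2 values shown sits). For the measured compounds named here, compound 2 thus holds the only number in this assay, the other value being a limit.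

Compound 3 `Cn1cc(/C=C2/C(=O)Nc3ccccc32)c2cc(Nc3nccc(-c4cccs4)n3)ccc21` differs from compound 2 by thiophen-2-yl in place of 4-chlorophenyl on an aromatic carbon. The step from compound 1 to compound 2 bears on it only in that it concerns the same position; it shows that what sits there can move the number a great deal, but it does not show which way a thiophen-2-yl will move it. A step beyond the scatter in either direction remains possible, with a modest loss taken as the central case. Compound 3 is therefore expected to give 5000 nM, with a range from 1000 nM to 40000 nM; the expected step is a 2.1-fold higher number from compound 2 to compound 3 (0.31 log units; beyond the scatter).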

Compound 3, half-maximal inhibitory concentration: 7940 nM
Compound 3: the middle estimate sits 1.6-fold (0.20 log units) below what was measured; low and high end bracket the measured number.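

At this position, on an aromatic carbon next to the ring nitrogen, a five-membered aromatic ring now has a measured place: in this assay, thiophen-2-yl in place of 4-chlorophenyl gives a 3.3-fold higher number from compound 2 to compound 3 (0.51 log units; beyond the scatter). Thiophen-2-yl in place of 4-methoxyphenyl gives an at least 12-fold lower number from compound 1 to compound 3 (1.10 log units; beyond the scatter), so 4-chlorophenyl is not the only group here that yields a readable number, and 4-methoxyphenyl alone of the three ends at a limit. That second step is a bound and not a measured size: the limit of > 100000 nM in this assay, at which 1 of the 3 values shown sits.

On these data alone, the three compounds carry only aromatic rings at this position, so the effect of an amine such as morpholine, a carboxylic acid or a plain alkyl chain there remains open. Also open, as far as these compounds go, is whether the difference between compound 2 and compound 3 follows the ring or the chlorine; an unsubstituted phenyl would separate the two.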